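A Second Trifluoromethyl on a Hydrazone at the Limit

This account rests on a few compounds, and the source may have more. Where it says the series, first, only, none or still open, it means among the compounds named here.

Going by the values given here, compound 3 `CNc1nc(C(F)(F)F)c(C(=O)N/N=C/c2cccc(C(F)(F)F)c2)s1` is one of three compounds measured in a functional assay on HeLa cells (Homo sapiens) for inhibition, read by MTT assay, with a stated time of 72 h; a lower number here means a stronger inhibitor, a higher number a weaker inhibitor. For compound 3 the result is only a limit of the assay, > 100 ug/mL. Compound 2 `CNc1nc(C)c(C(=O)N/N=C/c2cc(C(F)(F)F)cc(C(F)(F)F)c2)s1` likewise reaches only a limit in this assay, > 100 ug/mL. Compound 1 `CN(C(=O)NC(=O)c1ccccc1F)c1nc(C(F)(F)F)c(C(=O)N/N=C/c2cc(C(F)(F)F)cc(C(F)(F)F)c2)s1` gives 4.98 ug/mL in this assay. Two of the three values thus sit at the limit of > 100 ug/mL in this assay, at which 2 of the 3 values shown sit, and compound 3 is among them. Compound 4 `CNc1nc(C(F)(F)F)c(C(=O)N/N=C/c2cc(C(F)(F)F)cc(C(F)(F)F)c2)s1` differs from compound 3 by trifluoromethyl in place of hydrogen on an aromatic carbon. Among the compounds with values here, no step between two measured compounds is available, but compound 2 carries the same doubly substituted ring as compound 4 and sits at the limit. The expected step is a number no higher from compound 3 to compound 4 (the limit leaves the size open), not beyond the scatter. Compound 4 is estimated at 100 ug/mL, between 30 ug/mL and 300 ug/mL, with a limit the most likely report.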

Compound 4, half-maximal inhibitory concentration: > 100 ug/mL
Compound 4: only a limit was reported (the forecaster's own chance of this, stated with the estimate: 70%); the middle value lies on the limit itself.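

In this assay compound 4 gives only a limit of the assay, > 100 ug/mL, and the steps to it from compound 2 and compound 3, themselves limits, cannot be read. The second trifluoromethyl alone therefore gives no measured value, whereas hydrogen in place of ((2-fluorophenyl)carbonyl)carbamoyl on the nitrogen gives an at least 20-fold higher number from compound 1 to compound 4 (1.30 log units; beyond the scatter). The limit now holds most of the set: the limit of > 100 ug/mL in this assay, at which 3 of the 4 values shown sit.

As far as these compounds go, it remains open what a single trifluoromethyl on the six-membered ring does when ((2-fluorophenyl)carbonyl)carbamoyl is present. From the compounds shown here alone, it also remains open whether a smaller group on that nitrogen, such as acetyl, gives a measurable number.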